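The source may hold more compounds than are shown below. What is called first, only, known or untested is meant among the compounds shown, and "the series" means these compounds.

Compound 3 `Cn1ncc(Cl)c1-c1cc(C(=O)N[C@@H]2CN[C@H](CC(=O)NCC(O)CO)C[C@H]2c2ccc(Cl)c(Cl)c2)oc1Cl` stands at the high end of the three numbers measured in a functional assay on LNCaP cells (Homo sapiens) for antiproliferative activity (a lower number here means a stronger inhibitor, a higher number a weaker inhibitor), giving 660 nM. Compound 1 `Cn1ncc(Cl)c1-c1cc(C(=O)N[C@@H]2CN[C@H](CC(=O)O)C[C@H]2c2ccc(Cl)c(Cl)c2)oc1Cl` gives 640 nM in this assay, and the step of a 1.0-fold higher number from compound 1 to compound 3 (0.01 log units; within the scatter) lies within the scatter. Compound 2 `C=CC[C@@H]1C[C@@H](c2ccc(Cl)c(Cl)c2)[C@H](NC(=O)c2cc(-c3c(Cl)cnn3C)c(Cl)o2)CN1` gives 160 nM in this assay, and the step of a 4.1-fold higher number from compound 2 to compound 3 (0.62 log units; beyond the scatter) is modest but beyond the scatter. Compound 4 `Cn1ncc(Cl)c1-c1cc(C(=O)N[C@@H]2CN[C@H](CCO)C[C@H]2c2ccc(Cl)c(Cl)c2)oc1Cl` differs from compound 3 by hydroxymethyl in place of (2,3-dihydroxypropyl)carbamoyl on a saturated chain carbon bound to a saturated ring carbon. Because the step of a 1.0-fold higher number from compound 1 to compound 3 (0.01 log units; within the scatter) is flat while the step of a 4.1-fold higher number from compound 2 to compound 3 (0.62 log units; beyond the scatter) favours the smaller group at this chain carbon, compound 4 is expected to land between those two, with the expected step of a 2.1-fold lower number from compound 3 to compound 4 (0.31 log units; beyond the scatter). Compound 4 is therefore estimated to give 320 nM in this assay, within a range from 150 nM to 700 nM.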

Compound 4, half-maximal inhibitory concentration: 160 nM
The estimate for compound 4 lay 2.0-fold (0.30 log units) above the measured number; the measured number falls inside the stated range.
By their numbers in this assay, from the lowest: compounds 2 and 4 (each within the scatter of the next); then compounds 1 and 3 (each within the scatter of the next).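

In this assay, hydroxymethyl gives a 4.1-fold lower number from compound 3 to compound 4 (0.62 log units; beyond the scatter) and a 4.0-fold lower number from compound 1 to compound 4 (0.60 log units; beyond the scatter), while no change at the digits printed from compound 2 to compound 4 (within the scatter). Vinyl was previously the only group at this saturated chain carbon to separate from the others, and hydroxymethyl now matches it, so among these four compounds the two with a carbonyl on this chain, compounds 1 and 3, give the higher numbers. No evidence available here explains this difference. Whether the carbonyl itself accounts for it remains open. An amine, a methyl ether or a longer chain ending in hydroxyl at this place would test that reading.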